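Lengthening the Phenylalkyl Thioether Chain on a Shared Core

A few compounds are considered here, and "the series" means these few. Any claim that something is new, unique, unknown or untested is made for them only; others in the source may bear on it.

Compound 1, `CCCSc1nc2nc(C)cc(N3CC[C@@H](C)[C@@H](N(C)c4ncnc5[nH]ccc45)C3)n2n1`: 15500 nM
Compound 2, `Cc1cc(N2CC[C@@H](C)[C@@H](N(C)c3ncnc4[nH]ccc34)C2)n2nc(SCc3nc4ccccc4[nH]3)nc2n1`: 21200 nM
Compound 3, `Cc1cc(N2CC[C@@H](C)[C@@H](N(C)c3ncnc4[nH]ccc34)C2)n2nc(SCCc3ccccc3)nc2n1`: 6190 nM

All three were tested in a functional assay on MGC-803 cells (Homo sapiens) for inhibition, read by MTT assay, with a stated time of 72 h; a lower number here means a stronger inhibitor, a higher number a weaker inhibitor. Compound 3 gives the lowest number of the three, since a 2.5-fold lower number from compound 1 to compound 3 (0.40 log units; beyond the scatter) and a 3.4-fold lower number from compound 2 to compound 3 (0.53 log units; beyond the scatter) both lie beyond the scatter. Compound 4, `Cc1cc(N2CC[C@@H](C)[C@@H](N(C)c3ncnc4[nH]ccc34)C2)n2nc(SCCCc3ccccc3)nc2n1`, differs from compound 3 as follows: benzyl in place of phenyl on a saturated chain carbon, two bonds along the chain from a sulfur. Among the compounds with values here, no measured pair changes the chain in exactly this way, so the bearing steps are indirect: phenyl in place of methyl two bonds along the chain from a sulfur gave a modest gain, and benzyl in place of 1H-benzimidazol-2-yl on the sulfur-bound carbon gave a similar modest gain. Adding one more chain carbon has no precedent here, so the step of a 1.1-fold lower number from compound 3 to compound 4 (0.05 log units; within the scatter) is expected to stay within the scatter. Compound 4 is therefore estimated at 5500 nM, within 2000 nM to 15000 nM.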

Compound 4, half-maximal inhibitory concentration: > 100000 nM
Compound 4 was reported as a limit; the forecaster's own chance of this, stated with the estimate: 5%; at least 18-fold (1.25 log units) between middle value and limit.
By their numbers in this assay, from the lowest: compound 3; then compounds 1 and 2 (each within the scatter of the next). At a limit, above all of these: compound 4.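

Compound 4 is reported only as a limit, not as a number: the limit of > 100000 nM in this assay, at which 1 of the 4 values shown sits. The earlier steps shown here were modest at most, whereas adding one carbon, from phenethylsulfanyl to (3-phenylpropyl)sulfanyl, gives an at least 16-fold higher number from compound 3 to compound 4 (1.20 log units; beyond the scatter). So a longer chain at this place does not keep helping, and the 3-phenylpropyl chain also loses to the other two thioethers, with an at least 4.7-fold higher number from compound 2 to compound 4 (0.67 log units; beyond the scatter) and an at least 6.4-fold higher number from compound 1 to compound 4 (0.80 log units; beyond the scatter).

The compounds shown cannot tell why one carbon costs so much. From the compounds shown here alone, what a 4-phenylbutyl chain, or a propyl chain ending in an amine instead of phenyl, would give remains open.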